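A few compounds are considered here, and "the series" means these few. Any claim that something is new, unique, unknown or untested is made for them only; others in the source may bear on it.

Working notes on the series. All compounds share one core, and the variation lies in the side chain on its aromatic nitrogen. Compound 1 `O=C1c2c[n+]([O-])c3ccccc3c2C(=O)c2c1c1ccccc1n2Cc1cn(C[C@@H](O)CO)nn1` bears the 1-(2,3-dihydroxypropyl)-1H-1,2,3-triazol-4-yl group drawn with a defined configuration, and in a functional assay on MDA-MB-231 cells (Homo sapiens) for cytotoxicity, read by MTT assay, with a stated time of 72 h (on this read-out higher numbers stand for weaker inhibition and lower numbers for stronger inhibition), compound 1 gives 670 nM. Compound 2 `O=C1c2c[n+]([O-])c3ccccc3c2C(=O)c2c1c1ccccc1n2Cc1cn(CC(O)CO)nn1` is the same structure drawn without that configuration, and compound 2 gives 1290 nM; the step of a 1.9-fold higher number from compound 1 to compound 2 (0.28 log units; within the scatter) goes with the fact that one of compounds 1 and 2 is drawn with a defined configuration and the other without, at the place where they differ. Compound 3 `O=C1c2c[n+]([O-])c3ccccc3c2C(=O)c2c1c1ccccc1n2CCCCN1CCNCC1`, with 3-(piperazin-1-yl)propyl in place of the triazolyl group, gives 3310 nM, the highest of the three numbers shown: the steps of a 4.9-fold higher number from compound 1 to compound 3 (0.69 log units; beyond the scatter) and a 2.6-fold higher number from compound 2 to compound 3 (0.41 log units; beyond the scatter) both point the same way.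

Compound 4 `CN(C)CCCCn1c2c(c3ccccc31)C(=O)c1c[n+]([O-])c3ccccc3c1C2=O` is not yet measured. It differs from compound 3 as follows: dimethylamino in place of piperazin-1-yl on a saturated chain carbon, four bonds along the chain from an aromatic nitrogen. Going by the values given here, no measured step concerns this change. The two steps into compound 3 exchange the whole triazolyl group, and the step from compound 1 to compound 2 concerns only a drawn configuration, so none bears directly on the change to compound 4. Among the compounds with values here, with no comparable step in hand, the expectation for compound 4 is a small step of no settled direction, a 1.1-fold lower number from compound 3 to compound 4 (0.04 log units; within the scatter). Compound 4 is accordingly estimated at 3000 nM, with a range from 1200 nM to 7500 nM.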

Compound 4, half-maximal inhibitory concentration: 350 nM
Compound 4: the middle estimate sits 8.6-fold (0.93 log units) above what was measured; measured number outside the range, below it.
By their numbers in this assay, from the lowest: compounds 4, 1 and 2 (each within the scatter of the next, the first and the last beyond it); then compound 3.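

Going by these compounds alone, with the chain held constant, dimethylamino in place of piperazin-1-yl gives a 9.5-fold lower number from compound 3 to compound 4 (0.98 log units; beyond the scatter) in this assay and shows that the end group at this place, four bonds along the chain from an aromatic nitrogen, moves the number on its own, which the earlier steps could not show since they exchanged the whole side chain. Within the data shown here, the high number of compound 3 against the triazolyl compounds therefore does not hold for both amines on this chain: 3-(dimethylamino)propyl in place of the triazolyl group gives a 3.7-fold lower number from compound 2 to compound 4 (0.57 log units; beyond the scatter) while a 1.9-fold lower number from compound 1 to compound 4 (0.28 log units; within the scatter) leaves no separation from the compound drawn with a defined configuration. The information at hand concerns only a drawn configuration and gives no cause for the new step.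

Among these compounds, with only two end groups at this place, the series leaves open how morpholin-4-yl, piperidin-1-yl, diethylamino or 4-methylpiperazin-1-yl would read on the same chain. Also open, from the compounds shown here alone, is how dimethylamino would read on a shorter or longer chain.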